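From compound 2 to compound 3: a 3-ethylphenyl swap

The source may hold more compounds than are shown below. What is called first, only, known or untested is meant among the compounds shown, and "the series" means these compounds.

Compound 2 `Cc1nn(-c2ccccc2)c2nc(-c3ccc4c(c3)OCCO4)c(C#N)c(-c3ccccc3O)c12` was tested in an ADME assay on BJ cells (Homo sapiens) for cytotoxicity, with a stated time of 72 h; on this read-out lower numbers stand for an effect already at smaller amounts and higher numbers for an effect only at larger amounts of compound. Compound 2 gives > 20000 nM, which is a limit of the assay and not a number. Compound 1 `Cc1nn(-c2ccccc2)c2nc(-c3ccc(S(C)(=O)=O)cc3)c(C#N)c(-c3ccccc3O)c12` gives > 20000 nM in this assay, and this too is a limit. The evidence so far is therefore (the limit of > 20000 nM in this assay, at which 2 of the 2 values shown sit), and compound 2 has no numerical position of its own.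

Within the data shown here, the only measured step is a step that the two limits leave unreadable from compound 1 to compound 2, so it provides no size to carry forward. Compound 3 `CCc1cccc(-c2nc3c(c(C)nn3-c3ccccc3)c(-c3ccccc3O)c2C#N)c1` keeps the shared core and changes one group on an aromatic carbon, next to the ring nitrogen and ortho to a cyano group: 3-ethylphenyl in place of 2,3-dihydro-1,4-benzodioxin-6-yl on an aromatic carbon.

With that step unreadable, the expectation rests on compound 2 and its limit of > 20000 nM. No step beyond the scatter is expected in this assay, and another reading at the limit is thought more likely than a number. The estimated change is a number no higher from compound 2 to compound 3 (the limit leaves the size open). For compound 3 the expected value is 20000 nM, with an estimated range from 8000 nM to 40000 nM.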

Compound 3, half-maximal effective concentration in the BJ assay: > 20000 nM
Compound 3 was reported as a limit; the forecaster's own chance of this, stated with the estimate: 70%; the middle value lies on the limit itself.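

In the BJ assay compound 3 gives > 20000 nM, which is a limit of the assay and not a number. Among these compounds, no step among compound 1, compound 2 and compound 3 can be read. The compounds shown leave open whether the 4-(methylsulfonyl)phenyl, 2,3-dihydro-1,4-benzodioxin-6-yl and 3-ethylphenyl groups differ at all on this read-out: the limit of > 20000 nM in the BJ assay, at which 3 of the 3 values shown sit.

In a physicochemical assay for solubility, read by spectrophotometry, in phosphate buffer, with a stated time of 18 h, at pH 7.4 (a lower number here means a less soluble compound, a higher number a more soluble compound), compound 2 gives 11000 nM. In the physicochemical assay compound 3 gives 11000 nM. The swap of 2,3-dihydro-1,4-benzodioxin-6-yl for 3-ethylphenyl shows in the physicochemical assay no change at the digits printed from compound 2 to compound 3 (within the scatter).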